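Phenyl for hydroxyethyl on the alkyne of the uridine series

The source may report more compounds than this note shows. Statements on the series, on what has been measured and on what is new or still open speak of the compounds shown alone.

Compound 2 `O=c1[nH]c(=O)n([C@H]2C[C@H](O)[C@@H](CO)O2)cc1C#CCCO` stands at the weak end of the two measured values: in an ADME assay on L1210/0 cells (Mus musculus) for cytotoxicity, with a stated time of 48 h (on this read-out lower numbers stand for stronger inhibition and higher numbers for weaker inhibition), compound 2 gives only a limit, > 200000 nM, as recorded in the limit of > 200000 nM in this assay, at which 1 of the 2 values shown sits. Compound 1 `C=C(Cl)c1cn([C@H]2C[C@H](O)[C@@H](CO)O2)c(=O)[nH]c1=O` gives a number in this assay, 1660 nM. Among the measured compounds shown here, the single measured step is an at least 120-fold higher number from compound 1 to compound 2 (2.08 log units; beyond the scatter). Both that step and the present change alter the group on the aromatic carbon of the shared core.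

Compound 3 `O=c1[nH]c(=O)n([C@H]2C[C@H](O)[C@@H](CO)O2)cc1C#Cc1ccccc1` differs from compound 2 as follows: phenyl in place of 2-hydroxyethyl on a triple-bonded carbon. The 4-hydroxybut-1-yn-1-yl to 2-phenylethynyl change keeps the triple bond that went with the limit, so no return toward the value of compound 1 is expected with confidence; since compound 2 is a limit, the size of any step cannot be fixed. Compound 3 is expected to give 100000 nM, within 20000 nM to 300000 nM, the step being an at least 2.0-fold lower number from compound 2 to compound 3 (0.30 log units; that floor lies within the scatter) as estimated, with a fair chance that this assay reports only a limit again.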

Compound 3, half-maximal inhibitory concentration: > 200000 nM
Compound 3: no number, only a limit; the forecaster's own chance of this, stated with the estimate: 45%; middle value at least 2.0-fold (0.30 log units) from the limit.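

In this assay compound 3 also gives only a limit, > 200000 nM, so phenyl in place of 2-hydroxyethyl on the triple-bonded carbon yields no readable number. The step between compound 2 and compound 3 cannot be read, and neither group can be ranked over the other. Compared with 1-chloroethenyl, 2-phenylethynyl gives an at least 120-fold higher number from compound 1 to compound 3 (2.08 log units; beyond the scatter), so a second, quite different group on the triple bond ends at the same limit as the first: the limit of > 200000 nM in this assay, at which 2 of the 3 values shown sit.

From the compounds shown here alone, how far the true values of compound 2 and compound 3 lie past that limit stays open. Also open, going by these compounds, is whether the triple bond itself goes with the limit, or whether a terminal amine on the chain or a 1-bromoethenyl group on the aromatic carbon would give a readable number.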